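The source may report more compounds than this note shows. Statements on the series, on what has been measured and on what is new or still open speak of the compounds shown alone.

Measured so far:
Compound 1 `CC1=NN(c2ccccc2)C(=O)[C@@]12C(=O)C=CC[C@H]2c1ccc(C)cc1`: 6090 nM
Compound 2 `CC1=NN(c2ccccc2)C(=O)[C@@]12C(=O)C=CC[C@@H]2c1ccc(C)cc1`: 6570 nM

In a functional assay on A549 cells (Homo sapiens) for inhibition, read by MTT assay, with a stated time of 72 h (on this read-out higher numbers stand for weaker inhibition and lower numbers for stronger inhibition), compound 1 gives 6090 nM and compound 2 gives 6570 nM. Going by the values given here, compound 1 therefore stands level with the only other compound measured, since the numbers show a 1.1-fold higher number from compound 1 to compound 2 (0.03 log units; within the scatter). What separates the pair is the fact that compounds 1 and 2 differ only in the configuration as drawn.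

The next compound is compound 3 `CC1=NN(c2ccccc2)C(=O)[C@@]12C(=O)C=CC[C@H]2c1ccccc1`, which keeps the core of compound 1 and changes one substituent: hydrogen in place of methyl on an aromatic carbon. Hydrogen takes the place of methyl on an aromatic carbon, so 4-methylphenyl becomes phenyl.

Among the compounds with values here, only one measured step exists, a 1.1-fold higher number from compound 1 to compound 2 (0.03 log units; within the scatter), and it concerns configuration, not this group. It shows that this series can tolerate one structural change without a real shift in this assay, but it gives no direct size for losing the methyl. The expectation is therefore weakly founded, and no step beyond the scatter is anticipated. The estimate amounts to a 1.1-fold higher number from compound 1 to compound 3 (0.06 log units; within the scatter), an expected step of no clear direction. The expected value for compound 3 is 7000 nM, with an estimated range of 2800 nM to 17000 nM.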

Compound 3, half-maximal inhibitory concentration: 3770 nM
Beside the measured number, compound 3's estimate is 1.9-fold (0.27 log units) above it; the range from low to high includes it.
By their numbers in this assay, from the lowest: compounds 3, 1 and 2 (each within the scatter of the next).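

Going from 4-methylphenyl to phenyl gives a 1.6-fold lower number from compound 1 to compound 3 (0.21 log units; within the scatter) in this assay, and this is the first reading on the substituent itself, since the only earlier step concerned configuration. At this aromatic carbon, para to a large group, the methyl can therefore be replaced by hydrogen without any shift that stands clear of the usual scatter, so this methyl is not required for the activity seen in this series. The evidence at hand does not speak to this methyl or to why the swap leaves the reading within the scatter.

The compounds shown compare only methyl and hydrogen at this carbon, so it remains open whether a different group there, such as a methoxy group, an amine or a carboxylic acid, would move the number beyond the scatter in either direction. On these data alone, it also remains open whether the same change would read alike on the configuration of compound 2, or whether changes elsewhere on the shared core matter more than this one.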